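Sulfonyl on the ring nitrogen: a cytotoxicity series

A few compounds are considered here, and "the series" means these few. Any claim that something is new, unique, unknown or untested is made for them only; others in the source may bear on it.

Measured compounds:
compound 1 `O=C1/C(=C/c2ccncc2)CNC/C1=C\c1ccccc1F`: 8200 nM
compound 2 `O=C1/C(=C/c2ccncc2)CN(S(=O)(=O)c2ccccc2)C/C1=C\c1ccccc1F`: 5800 nM
compound 3 `O=C1/C(=C/c2cccnc2)CNC/C1=C\c1ccccc1C(F)(F)F`: 5020 nM

The three compounds were tested in a functional assay on HepG2 cells (Homo sapiens) for cytotoxicity, read by MTT assay, with a stated time of 24 h; a higher number here means a weaker inhibitor, a lower number a stronger inhibitor. Compound 1 gives 8200 nM in this assay, and compound 2, which carries phenylsulfonyl in place of hydrogen on an amine nitrogen in a ring, gives 5800 nM; the step is a 1.4-fold lower number from compound 1 to compound 2 (0.15 log units; within the scatter). Compound 3 gives 5020 nM in this assay; the difference between the core of compound 3 and the core of compound 1 is not broken down here, and the two values lie within the scatter of each other.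

Compound 4 `O=C1/C(=C/c2cccnc2)CN(S(=O)(=O)c2ccccc2)C/C1=C\c1ccccc1C(F)(F)F` has not been measured. It differs from compound 3 by phenylsulfonyl in place of hydrogen on an amine nitrogen in a ring, the same change that separates compound 2 from compound 1. Because compound 2 stands a 1.4-fold lower number from compound 1 to compound 2 (0.15 log units; within the scatter) from compound 1, the step to compound 4 is expected to be of similar modest size, a 1.4-fold lower number from compound 3 to compound 4 (0.14 log units; within the scatter). In this assay compound 4 is therefore estimated at 3600 nM, most likely between 1800 nM and 7500 nM, resting on a single earlier example of this change.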

Compound 4, half-maximal inhibitory concentration: 5370 nM
Beside the measured number, compound 4's estimate is 1.5-fold (0.17 log units) below it; the measured number falls inside the stated range.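

In this assay, among the compounds shown here, phenylsulfonyl in place of hydrogen on an amine nitrogen in a ring gives a 1.1-fold higher number from compound 3 to compound 4 (0.03 log units; within the scatter), so on this core the change leaves no step that can be told from the scatter. Set beside the earlier example, the two steps do not differ measurably: the same change on two cores in this assay, a 1.4-fold lower number (0.15 log units; within the scatter) from compound 1 to compound 2 and a 1.1-fold higher number (0.03 log units; within the scatter) from compound 3 to compound 4, 1.5-fold (0.18 log units) apart, within the scatter of two such steps. This shows that the change carried over from the core of compound 1 to the core of compound 3 without a distinct shift in either case, but it does not show that phenylsulfonyl alters the cytotoxicity reading on either core, and two pairs say nothing about further cores.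

The compounds shown leave open whether an acetyl group, a methylsulfonyl group or a benzyl group on the same ring nitrogen would give a step beyond the scatter. They also leave open what a phenylsulfonyl group carrying an amine or a carboxylic acid would do, and how the two cores compare one substituent at a time.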